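This account rests on a few compounds, and the source may have more. Where it says the series, first, only, none or still open, it means among the compounds named here.

Compound 1 `NC(=O)c1cc(Cl)ccc1NC(=O)COc1ccccc1`: 9010 nM
Compound 2 `NC(=O)c1cc(I)ccc1NC(=O)COc1ccccc1`: 1280 nM

In a functional assay on MDA-MB-231 cells (Homo sapiens) for inhibition (on this read-out higher numbers stand for weaker inhibition of growth and lower numbers for stronger inhibition of growth), compound 2 has the lower of the two numbers, at 1280 nM. The next structure, compound 3 `COc1ccc(NC(=O)COc2ccccc2)c(C(N)=O)c1`, differs from it in one place: methoxy in place of iodo on an aromatic carbon. In words, this is methoxy in place of iodo on an aromatic carbon, para to a large group.

Going by the values given here, only one measured step bears on this change: a 7.0-fold lower number from compound 1 to compound 2 (0.85 log units; beyond the scatter). It is a modest step, with iodo in place of chloro on an aromatic carbon. Among the compounds with values here, no measured compound carries methoxy, so this single step is only a weak guide. Within the data shown here, still, the one compound without iodo, compound 1, shows the higher number at 9010 nM, so a higher number in this assay, meaning weaker inhibition of growth, is expected on leaving iodo.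

The estimate is a 4.7-fold higher number from compound 2 to compound 3 (0.67 log units; beyond the scatter). For compound 3 the expected value is 6000 nM, with an estimated range of 1800 nM to 20000 nM.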

Compound 3, concentration for 50% growth inhibition: 2030 nM
For compound 3 the middle estimate is 3.0-fold (0.47 log units) above the measured one; the range from low to high includes it.
By their numbers in this assay, from the lowest: compounds 2 and 3 (each within the scatter of the next); then compound 1.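

At this position, para to a large group, swapping iodo for methoxy gives a 1.6-fold higher number from compound 2 to compound 3 (0.20 log units; within the scatter) in this assay, so the two groups cannot be told apart here. Going by these compounds alone, this shows that iodo is not the only group that separates from chloro, since the other new step is a 4.4-fold lower number from compound 1 to compound 3 (0.65 log units; beyond the scatter). Iodo is a single heavy atom with no hydrogen-bond acceptor, whereas methoxy has two heavy atoms and one acceptor, so these counts do not by themselves set the number in this small set.

No measurement is available that explains why chloro stands apart from the other two groups. Also open, going by these compounds, is whether an amine, a hydroxyl or a longer chain such as ethoxy at this position would stay with iodo and methoxy or fall back towards chloro.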